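The compounds below may be only part of what the source reports. "The series", "measured", "known", "first", "only" and "open" are said of these compounds alone.

Measured in an assay on cells for inhibition of Aromatase (Homo sapiens), with a stated time of 30 min; a higher number here means a weaker inhibitor, a lower number a stronger inhibitor:

compound 1, `COc1cc(O)c(C=O)c2c1[C@H](O)C[C@@H](c1ccccc1)O2`: 40 nM
compound 2, `COc1c(C)c(OC)c2c(c1C=O)O[C@H](c1ccccc1)C[C@H]2O`: 1010 nM

Compound 1 holds the lowest number of the two measured in this assay. Compound 2 gives a markedly higher number, well beyond the scatter, but its structure differs from compound 1 in more than one place, so the two values alone do not isolate any single change.

Compound 3, `COc1cc(O)c(C=O)c2c1[C@H](OC)C[C@@H](c1ccccc1)O2`, is the next member. Relative to compound 1 it carries methyl in place of hydrogen on an oxygen on a saturated carbon. Within the data shown here, no pair of measured compounds shows this kind of change in this assay, so there is no measured step to lean on. The expectation is a small step, most likely a modest rise in the number, and possibly none beyond the scatter. The step from compound 1 to compound 3 is therefore estimated as a 2.0-fold higher number from compound 1 to compound 3 (0.30 log units; within the scatter). For compound 3 the estimated value in this assay is 80 nM, with a range from 20 nM to 400 nM.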

Compound 3, half-maximal inhibitory concentration: 90 nM
For compound 3 the middle estimate is 1.1-fold (0.05 log units) below the measured one; the range from low to high includes it.
By their numbers in this assay, from the lowest: compound 1; then compound 3; then compound 2.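

Hydroxy to methoxy on the oxygen on a saturated carbon is the first single-place change available in this series, and in this assay it reads as a 2.3-fold higher number from compound 1 to compound 3 (0.35 log units; beyond the scatter) and so costs only a modest step. The hydrogen on this oxygen can therefore be replaced by methyl without a large loss of inhibition, so a free hydroxy at this position is not required for activity in the low range of the series. No data at hand bear on why the step has this size.

Still open, as far as these compounds go, is how this position responds to anything other than methyl, such as a longer chain like ethyl or benzyl on the oxygen, an acetate ester, or an amine in place of the oxygen. The compounds shown also leave unassigned which of the several differences in compound 2 carries its higher number.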